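A few compounds are considered here, and "the series" means these few. Any claim that something is new, unique, unknown or untested is made for them only; others in the source may bear on it.

Measured so far in an ADME assay (liver) for metabolic stability, with Liver microsome (Rattus norvegicus) as the target, read by LC-MS, using microsomes, with a stated time of 30 min, tested at 4 uM; on this read-out lower numbers stand for a less stable compound and higher numbers for a more stable compound:
- Compound 1 `Cc1nc(N2CCN(C)CC2)c2nc(-c3ccccc3Cl)n(C3CC3)c2n1` gives 44%
- Compound 2 `CCN1CCN(c2nc(C)nc3c2nc(-c2ccccc2Cl)n3CC2CCOCC2)CC1` gives 80%
- Compound 3 `Cc1nc(N2CCN(C)CC2)c2nc(-c3ccccc3C(F)(F)F)n(C3CCOCC3)c2n1` gives 38%

Compound 3, at 38% and so the lowest number here, still sits within the usual scatter of compound 1 and counts as level with it. Compound 2 lies well above both, beyond the scatter.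

Compound 4 `Cc1nc(N2CCN(C)CC2)c2nc(-c3ccccc3C)n(C3CCOCC3)c2n1` differs from compound 3 in one place: methyl in place of trifluoromethyl on an aromatic carbon, ortho to a large group (methyl in place of trifluoromethyl on an aromatic carbon). Among the compounds with values here, no pair of measured compounds shows this swap, so the data offer no direct guide. The expected step (a number 5 percentage points lower from compound 3 to compound 4 (within the scatter)) is small and downward and stays within the scatter. The estimated value for compound 4 is 33% (expected range 15% to 52%).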

Compound 4, percent of the compound remaining: 39%
The estimate for compound 4 lay 6 percentage points below the measured number, and the stated range covers the measured number.
By their numbers in this assay, from the lowest: compounds 3, 4 and 1 (each within the scatter of the next); then compound 2.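

In this assay, putting methyl in place of trifluoromethyl on this aromatic carbon gives a number 1 percentage points higher from compound 3 to compound 4 (within the scatter) and so leaves the read-out level. With everything else in the molecule held the same, this assay does not tell the 2-(trifluoromethyl)phenyl and 2-methylphenyl forms apart. Nothing at hand explains this result.

Still open, as far as these compounds go, is whether a different group at this place, such as a methoxy group, an amine or a carboxylic acid, would move the number. From the compounds shown here alone, it is also open whether the same swap would stay level with other groups elsewhere on the shared core.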